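Chloromethylbenzyl purines: amino in place of chloro

A few compounds are considered here, and "the series" means these few. Any claim that something is new, unique, unknown or untested is made for them only; others in the source may bear on it.

compound 1 `ClCc1ccccc1Cn1cnc2c(Cl)nc(Cl)nc21` — 1450 nM
compound 2 `Nc1nc(Cl)c2ncn(Cc3ccc(CCl)cc3)c2n1` — 16600 nM
compound 3 `ClCc1ccccc1Cn1cnc2ncnc(Cl)c21` — 3460 nM

In a functional assay on TK-10 cells (Homo sapiens) for cytotoxicity, read by sulforhodamine B assay, with a stated time of 48 h (a higher number here means a weaker inhibitor of growth, a lower number a stronger inhibitor of growth), compound 1 gives 1450 nM, the lowest number of the three. Compound 3 gives 3460 nM and compound 2 gives 16600 nM; both gaps from compound 1 lie beyond the scatter. For the measured compounds named here, no two measured compounds differ in a single place, so those pairs show only their two values.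

Compound 4 `Nc1nc(Cl)c2ncn(Cc3ccccc3CCl)c2n1` is not yet measured. It differs from compound 1 by amino in place of chloro on an aromatic carbon. Going by the values given here, no measured step of this kind exists. Compound 2, which also carries amino at that position, gives 16600 nM, the highest number seen, so a weakening beyond the scatter is expected. Compound 4 is estimated at 6000 nM, range 2000 nM to 20000 nM. The expected step is a 4.1-fold higher number from compound 1 to compound 4 (0.62 log units; beyond the scatter).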

Compound 4, concentration for 50% growth inhibition: 17800 nM
Estimate against measurement, compound 4: 3.0-fold (0.47 log units) below, within the range that was stated.
By their numbers in this assay, from the lowest: compound 1; then compound 3; then compounds 2 and 4 (each within the scatter of the next).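

a 12-fold higher number from compound 1 to compound 4 (1.09 log units; beyond the scatter) is the first reading of this change in this assay: amino in place of chloro, on the aromatic carbon between two ring nitrogen atoms, brings a large loss of growth inhibition. The position is therefore not indifferent to its substituent, although this rests on a single pair. No measurement at hand gives a reason for the loss. Still open, going by these compounds, is whether methoxy, methylamino or dimethylamino at this carbon would stay close to compound 1 or fall near compound 4. Also open, on these data alone, is whether a hydrogen there would give a smaller step.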